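Expected Cytotoxicity of a Chloro Analogue of Compound 1

The compounds below may be only part of what the source reports. "The series", "measured", "known", "first", "only" and "open" are said of these compounds alone.

Compound 1 `CC(C)Nc1nc(NCc2ccco2)c2ccccc2n1` gives 17000 nM in an ADME assay on J774.A1 cells (Mus musculus) for cytotoxicity, read by MTT assay, with a stated time of 72 h; on this read-out lower numbers stand for an effect already at smaller amounts and higher numbers for an effect only at larger amounts of compound.
Compound 2 `CC(C)Nc1nc(N(C)C)c2ccccc2n1` gives only a limit of this assay, > 33000 nM.

In this assay compound 1 holds the only number shown, the other value being a limit (the limit of > 33000 nM in this assay, at which 1 of the 2 values shown sits). Among the compounds with values here, the single measured step, an at least 1.9-fold higher number from compound 1 to compound 2 (0.28 log units; that floor lies within the scatter), concerns a different change on the shared core. Compound 3 `CC(C)Nc1nc(NCc2ccco2)c2cccc(Cl)c2n1` differs from compound 1 by chloro in place of hydrogen on an aromatic carbon. Within the data shown here, no measured step touches this change, so for compound 3 no shift beyond the scatter is expected, no change at the digits printed from compound 1 to compound 3 (within the scatter). Compound 3 is therefore estimated at 17000 nM, between 8000 nM and 36000 nM.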

Compound 3, half-maximal effective concentration: > 33000 nM
Compound 3 was reported as a limit (the forecaster's own chance of this, stated with the estimate: 25%); at least 1.9-fold (0.28 log units) between middle value and limit.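

Within the data shown here, the chloro group gives the first reading at this position, on an aromatic carbon ortho to a fused ring: in this assay there is an at least 1.9-fold higher number from compound 1 to compound 3 (0.28 log units; that floor lies within the scatter). The value of compound 3 is a limit and not a number, so the step has only a floor and no measured size. Compound 3 thus shares its limit with compound 2, and compound 1 keeps the only number: the limit of > 33000 nM in this assay, at which 2 of the 3 values shown sit.

Going by these compounds, how far compound 3 truly lies from compound 1 stays open. Also open, on these data alone, is whether fluoro, methoxy or an amine on this carbon gives a number in this assay rather than a limit.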